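Cyclohexyl to 3-cyanophenyl: expected lipophilicity change

The compounds below may be only part of what the source reports. "The series", "measured", "known", "first", "only" and "open" are said of these compounds alone.

Compound 1 `CNC(=O)c1cc(C(=O)NCCCC2CNCCO2)cn(Cc2ccccc2)c1=O`: 1.4
Compound 2 `CNC(=O)c1cc(C(=O)NC2CC2)cn(CC2CCCCC2)c1=O`: 4
Compound 3 `CNC(=O)c1cc(C(N)=O)cn(Cc2ccccc2)c1=O`: 2

Of the compounds shown here, three sharing one core have been measured in a physicochemical assay for lipophilicity, at pH 7.4; a higher number here means a more lipophilic compound, a lower number a more polar compound. Compound 2 stands highest of the three, beyond the scatter from both others: compound 3 sits nearest, and compound 1 furthest. Among the measured compounds shown here, the one directly comparable pair is compound 1 and compound 3, where a number 0.60 log units higher from compound 1 to compound 3 (beyond the scatter) on the amide-type nitrogen gave a modest rise. Compound 4 `CNC(=O)c1cc(C(=O)NC2CC2)cn(Cc2cccc(C#N)c2)c1=O` has not yet been measured. It differs from compound 2 by 3-cyanophenyl in place of cyclohexyl on a saturated chain carbon bound to an aromatic nitrogen. For the measured compounds named here, no measured pair isolates this change: compound 2 and compound 3 differ both there and at the amide, so their values can only be compared, not read as a step. Compound 4 is therefore expected to lie below compound 2, at an estimated 2.7 with a range from 2.1 to 3.3. This estimate corresponds to an expected a number 1.30 log units lower from compound 2 to compound 4 (beyond the scatter), a drop beyond the scatter.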

Compound 4, distribution coefficient: 2.6
The estimate for compound 4 lay 0.10 log units above the measured number, within the range that was stated.
By their numbers in this assay, from the lowest: compound 1; then compound 3; then compound 4; then compound 2.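

Among the compounds shown here, compound 2 and compound 4 form the first pair to isolate a change on the saturated chain carbon bound to an aromatic nitrogen, and in this assay the move from cyclohexyl to 3-cyanophenyl gave a number 1.40 log units lower from compound 2 to compound 4 (beyond the scatter) as a single-place step. The position therefore responds strongly to this exchange, and this large step exceeds the modest one at the amide-type nitrogen, a number 0.60 log units higher from compound 1 to compound 3 (beyond the scatter), which runs in the opposite direction. No available evidence gives a reason for the size of the step.

On these data alone, how much of it goes with the aromatic ring and how much with the nitrile remains open, as both enter together. As far as these compounds go, the reading in this assay for a carboxylic acid or an amine in place of the nitrile on that ring also remains open.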